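Pyrazinylmethyl in place of thiophenylmethyl on a shared amine

This account rests on a few compounds, and the source may have more. Where it says the series, first, only, none or still open, it means among the compounds named here.

Measured compounds:
compound 1 `Nc1nc(NCc2cccs2)nc2sc(-c3ccco3)nc12` — 75 nM
compound 2 `Nc1nc(NCc2ccco2)nc2sc(-c3ccco3)nc12` — 82 nM
compound 3 `Nc1nc(NCc2ccccn2)nc2sc(-c3ccco3)nc12` — 95 nM

All three share one core and differ only in the aromatic ring carried on the saturated chain carbon bound to a nitrogen on the core. In a functional assay on CHO cells for agonist activity at adenosine receptor A2b (Homo sapiens), read by scintillation counting and cAMP accumulation, with a stated time of 150 min, in the presence of a further agent that is not named here (on this read-out higher numbers stand for weaker inhibition and lower numbers for stronger inhibition), compound 1 gives 75 nM; the step of a 1.1-fold higher number from compound 1 to compound 2 (0.04 log units; within the scatter) and the step of a 1.3-fold higher number from compound 1 to compound 3 (0.10 log units; within the scatter) are both within the scatter, as is a 1.2-fold higher number from compound 2 to compound 3 (0.06 log units; within the scatter), so the three numbers cannot be told apart.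

Compound 4 `Nc1nc(NCc2cnccn2)nc2sc(-c3ccco3)nc12` has not been measured. It differs from compound 1 as follows: pyrazin-2-yl in place of thiophen-2-yl on a saturated chain carbon bound to a nitrogen on an aromatic ring. For the measured compounds named here, the nearest precedent is the step to compound 3, where a six-membered ring with one hetero atom replaced the thiophen-2-yl and gave a 1.3-fold higher number from compound 1 to compound 3 (0.10 log units; within the scatter), within the scatter. The furan-2-yl exchange in compound 2 likewise moved nothing beyond the scatter. Going by the values given here, a second ring nitrogen has no precedent among the measured compounds, so the expectation for compound 4 rests on compound 3 alone. The estimated step is a 1.5-fold higher number from compound 1 to compound 4 (0.17 log units; within the scatter), within the scatter. Compound 4 is therefore expected to give about 110 nM in this assay , with a range from 50 nM to 260 nM.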

Compound 4, half-maximal inhibitory concentration: 13.2 nM
Compound 4: the middle estimate sits 8.3-fold (0.92 log units) above what was measured, outside the stated range (below it).
By their numbers in this assay, from the lowest: compound 4; then compounds 1, 2 and 3 (each within the scatter of the next).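

In this assay, for the compounds shown here, the place on a saturated chain carbon bound to a nitrogen on an aromatic ring turns out to distinguish between rings, which the earlier compounds gave no sign of: pyrazin-2-yl stands apart from the other three rings, with a 5.7-fold lower number from compound 1 to compound 4 (0.75 log units; beyond the scatter), a 6.2-fold lower number from compound 2 to compound 4 (0.79 log units; beyond the scatter) and a 7.2-fold lower number from compound 3 to compound 4 (0.86 log units; beyond the scatter), all beyond the scatter. Ring size alone does not account for this pattern, as compound 3 also carries a six-membered aromatic ring yet cannot be told apart from compound 1 and compound 2, which carry five-membered ones, so the separation appears only with the six-membered ring that has two hetero atoms. No measurement at hand bears on why this one exchange separates from the others.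

From the compounds shown here alone, it remains open whether any second ring nitrogen goes with the lower number or only the arrangement in pyrazin-2-yl, which a pyrimidin-2-yl or pyridazin-3-yl ring would test, with a plain phenyl ring as the reference without any ring nitrogen. Also open, going by these compounds, is whether the step in this assay would persist if a group such as phenyl replaced the furan-2-yl on the shared core.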